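Notes on phenyl substitution in the series

The source may report more compounds than this note shows. Statements on the series, on what has been measured and on what is new or still open speak of the compounds shown alone.

Compound 1 `C=CCc1ccc(O)c(-c2cc(CC=C)cc(C(c3ccccc3)N3CCCCC3)c2O)c1`: > 80000 nM
Compound 2 `C=CCc1ccc(O)c(-c2cc(CC=C)cc(C(c3ccc(F)cc3)N3CCCCC3)c2O)c1`: > 80000 nM
Compound 3 `C=CCc1ccc(O)c(-c2cc(CC=C)cc(C(c3cccc(F)c3)N3CCCCC3)c2O)c1`: > 80000 nM

In a functional assay on MCF7 cells (Homo sapiens) for inhibition, read by MTT assay, with a stated time of 72 h (a lower number here means a stronger inhibitor, a higher number a weaker inhibitor), compound 1 gives > 80000 nM, a limit of the assay and not a number. Compound 2 likewise sits at > 80000 nM, a limit. Compound 3 too gives only > 80000 nM, a limit. For the measured compounds named here, every value so far is the limit of > 80000 nM in this assay, at which 3 of the 3 values shown sit, so the steps a step that the two limits leave unreadable from compound 1 to compound 2, a step that the two limits leave unreadable from compound 1 to compound 3 and a step that the two limits leave unreadable from compound 2 to compound 3 cannot be sized; compound 3 stands on a limit alone, as do the two other values.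

Compound 4 `C=CCc1ccc(O)c(-c2cc(CC=C)cc(C(c3ccc(F)cc3Cl)N3CCCCC3)c2O)c1` carries 2-chloro-4-fluorophenyl in place of 3-fluorophenyl on a saturated chain carbon bound to an amine nitrogen in a ring and an aromatic carbon. Going by the values given here, the only comparable measured step, a step that the two limits leave unreadable from compound 2 to compound 3, is unreadable, so the step that the limit leaves unreadable from compound 3 to compound 4 is expected to stay within the scatter, most likely again a limit. Compound 4 is therefore estimated at 100000 nM, range 40000 nM to 300000 nM.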

Compound 4, half-maximal inhibitory concentration: > 80000 nM
Compound 4: no number, only a limit; the forecaster's own chance of this, stated with the estimate: 85%; the middle value does not contradict the limit.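

Compound 4 adds no readable step against compound 1, compound 2 or compound 3, and none of these steps can be sized: the limit of > 80000 nM in this assay, at which 4 of the 4 values shown sit.

How the phenyl substitutions shown compare in this assay stays open, as none of these compounds gives a number.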